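The compounds below may be only part of what the source reports. "The series", "measured", "known", "first", "only" and "open" are said of these compounds alone.

Measured so far:
compound 1 `CCCS(=O)(=O)Nc1ccc(F)c(C(=O)c2n[nH]c3ncc(-c4cccc(F)c4)cc23)c1F` — 8.2%
compound 2 `CCCS(=O)(=O)Nc1ccc(F)c(C(=O)c2n[nH]c3ncc(-c4ccc(OC)cc4)cc23)c1F` — 4.2%
compound 3 `CCCS(=O)(=O)Nc1ccc(F)c(C(=O)c2n[nH]c3ncc(-c4cccc(O)c4)cc23)c1F` — 2.2%

In an assay for binding affinity to dual specificity mitogen-activated protein kinase kinase 4 (Homo sapiens), read by KINOMEscan, tested at 100 nM (a lower number here means a stronger effect, a higher number a weaker effect of the compound at the concentration tested), compound 3 gives the smallest of the three numbers, yet its gaps to compound 2 and to compound 1 both sit within the scatter. Compound 4 `CCCS(=O)(=O)Nc1ccc(F)c(C(=O)c2n[nH]c3ncc(-c4ccccc4N)cc23)c1F` is not yet measured; the change is 2-aminophenyl in place of 3-hydroxyphenyl on an aromatic carbon. All three measured steps vary the same aryl substituent: a number 4 percentage points lower from compound 1 to compound 2 (within the scatter), a number 6 percentage points lower from compound 1 to compound 3 (within the scatter) and a number 2 percentage points lower from compound 2 to compound 3 (within the scatter), none beyond the scatter. The ring substituent therefore shows no detectable effect across the three numbers, and for compound 4 no step beyond the scatter is expected, the estimated step being a number 2.3 percentage points higher from compound 3 to compound 4 (within the scatter). Compound 4 is estimated at 4.5%, with a range from 1% to 12%.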

Compound 4, a percentage reported as activity, at one concentration (the size of the read-out at that concentration, not a potency): 23%
For compound 4 the middle estimate is 18.5 percentage points below the measured one; the whole stated range lies below it.
By their numbers in this assay, from the lowest: compounds 3, 2 and 1 (each within the scatter of the next); then compound 4.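

In this assay the aryl position proves sensitive to the group it carries: the number is a number 20.8 percentage points higher from compound 3 to compound 4 (beyond the scatter), a number 18.8 percentage points higher from compound 2 to compound 4 (beyond the scatter) and a number 14.8 percentage points higher from compound 1 to compound 4 (beyond the scatter), which sets 2-aminophenyl apart from the three other aryl groups. The change from 3-hydroxyphenyl replaces oxygen with nitrogen and also moves the substituent around the phenyl ring, so these two differences cannot be separated here. No measured evidence bears on the origin of this rise. Still open, going by these compounds, is whether the amine itself or its ring position drives the rise; a phenyl ring carrying the amine at another carbon, or a carboxylic acid at the same carbon, would help to distinguish them.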